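Cyclohexyl in Place of Phenyl in Compound 2

This account rests on a few compounds, and the source may have more. Where it says the series, first, only, none or still open, it means among the compounds named here.

For the measured compounds named here, in a functional assay on NCI-H460 cells (Homo sapiens) for cytotoxicity, read by MTT assay, with a stated time of 72 h (on this read-out lower numbers stand for stronger inhibition and higher numbers for weaker inhibition), compound 2 (`O=c1[nH]/c(=C\c2cccc(Oc3ccc(F)cc3)c2)c(=O)[nH]/c1=C\c1ccccc1`) gives 389 nM as the higher of the two numbers so far, and compound 1 (`O=c1[nH]/c(=C\c2ccccn2)c(=O)[nH]/c1=C\c1cccc(Oc2ccc(F)cc2)c1`) gives 49.1 nM as the lower. Compound 3 (`O=c1[nH]/c(=C\C2CCCCC2)c(=O)[nH]/c1=C\c1cccc(Oc2ccc(F)cc2)c1`) has cyclohexyl in place of phenyl on a double-bonded chain carbon bound to an aromatic carbon and keeps everything else. Going by the values given here, one measured step touches this same place: phenyl in place of pyridin-2-yl gave a 7.9-fold higher number from compound 1 to compound 2 (0.90 log units; beyond the scatter) as the only guide. A step of similar size toward a higher number is therefore expected, so a 5.1-fold higher number from compound 2 to compound 3 (0.71 log units; beyond the scatter) is the estimated move in this assay from this single precedent. Compound 3 is estimated at 2000 nM with an expected range of 500 nM to 8000 nM.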

Compound 3, half-maximal inhibitory concentration: > 1000 nM
Compound 3: a limit, no number; the forecaster's own chance of this, stated with the estimate: 10%; the middle value is on the limit's open side.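

In this assay compound 3 gives only a limit, not a number: > 1000 nM. The steps, an at least 2.5-fold higher number from compound 2 to compound 3 (0.41 log units; beyond the scatter) and an at least 20-fold higher number from compound 1 to compound 3 (1.30 log units; beyond the scatter), show that this position is sensitive to more than the swap of pyridin-2-yl for phenyl, since replacing the aromatic ring with non-aromatic cyclohexyl also raises the number. Both sizes are minimums, because the true value of compound 3 remains unknown: the limit of > 1000 nM in this assay, at which 1 of the 3 values shown sits.

On these data alone, whether a pyridin-3-yl ring, an amine or an open butyl chain at this position would give a number nearer that of compound 1 remains open. The compounds shown also cannot explain why these rings differ.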